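This account rests on a few compounds, and the source may have more. Where it says the series, first, only, none or still open, it means among the compounds named here.

Measured in an assay on HEK293 cells for positive allosteric modulation of metabotropic glutamate receptor 2 (Rattus norvegicus), read by thallium flux, with a stated time of 2.5 min; a higher number here means a larger maximal response, a lower number a smaller maximal response:
compound 1 `Cc1c(OCCCCOc2ccc(C(=O)C(C)C)c(O)c2C)cccc1C(=O)O`, 66.9%
compound 2 `CCCC(=O)c1ccc(OCCCCOc2cc(C(=O)O)ccc2OC)c(C)c1O`, 82.8%
compound 3 `Cc1c(OCCCCOc2ccc(F)c(C(=O)O)c2)ccc(C(=O)CC2CCCC2)c1C`, 14.6%

On the three numbers at hand compound 1 stands second highest. Compound 2 sits above it by a margin beyond the usual scatter, and compound 3 sits well below it, again beyond the scatter. Compound 4 `Cc1c(OCCCCOc2ccc(C(=O)CC(C)(C)C)c(O)c2C)cccc1C(=O)O` is the next to be run in this assay. Relative to compound 1 the change is neopentyl in place of isopropyl on a carbonyl carbon. Going by the values given here, no pair of measured compounds differs in this place alone, so no measured step bears on it directly. With nothing to lean on, the expectation is a modest drop or none beyond the scatter: the expected step in this assay is a number 8.9 percentage points lower from compound 1 to compound 4 (within the scatter). Compound 4 is accordingly estimated at 58%, with a range from 35% to 80%.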

Compound 4, largest response reached (reported as percent of maximum), in percent of the reference or control that the assay uses: 95.8%
Compound 4: middle estimate off by 37.8 percentage points, on the low side; measured number outside the range, above it.
By their numbers in this assay, from the lowest: compound 3; then compound 1; then compound 2; then compound 4.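

On the carbonyl carbon of the core of compound 1, the alkyl group clearly matters in this assay: neopentyl in place of isopropyl gives a number 28.9 percentage points higher from compound 1 to compound 4 (beyond the scatter). This place therefore accepts a group of 5 heavy atoms in place of one of 3 with no loss of maximal response, and with a gain beyond the scatter. Nothing available explains this gain.

Still open, from the compounds shown here alone, is whether a hexyl chain or a chain ending in an amine on this carbonyl carbon would keep the response. Also open, going by these compounds, is whether neopentyl gives a similar gain on the cores of compound 2 and compound 3.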